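Cytotoxicity limits across a small related series

The compounds below may be only part of what the source reports. "The series", "measured", "known", "first", "only" and "open" are said of these compounds alone.

Compound 1 `O=[N+]([O-])c1cn2c(n1)OC(CNc1ccc(OC(F)(F)F)cc1)CC2`, compound 2 `CC1(CNc2ccc(OC(F)(F)F)cc2)CCn2cc([N+](=O)[O-])nc2O1` and compound 3 `O=C(NCC1CCn2cc([N+](=O)[O-])nc2O1)Nc1ccc(OC(F)(F)F)cc1` share a common core; how the core of compound 3 differs from that of compound 1 is not broken down here. In an ADME assay on MRC5 cells (Homo sapiens) for cytotoxicity, read by resazurin assay, with a stated time of 72 h (a higher number here means a weaker inhibitor, a lower number a stronger inhibitor), compound 1 gives >= 40000 nM, which is a limit of the assay rather than a number. Compound 2 gives >= 40000 nM, also a limit. Compound 3 gives >= 40000 nM, again a limit. The step that the two limits leave unreadable from compound 1 to compound 2, (methyl in place of hydrogen on a saturated ring carbon), therefore cannot be read, as the limit of >= 40000 nM in this assay, at which 3 of the 3 values shown sit, shows. Compound 4 `CC1(CNC(=O)Nc2ccc(OC(F)(F)F)cc2)CCn2cc([N+](=O)[O-])nc2O1` carries the same change against compound 3, (methyl in place of hydrogen on a saturated ring carbon), at a place described in identical words. Within the data shown here, since every value so far sits at the limit and no step is readable, compound 4 is expected to sit at the limit as well, an expected step that the limit leaves unreadable from compound 3 to compound 4. The estimate for compound 4 is 60000 nM.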

Compound 4, half-maximal inhibitory concentration: >= 40000 nM
Compound 4 was reported as a limit; the forecaster's own chance of this, stated with the estimate: 85%; the middle value is on the limit's open side.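

No step can be read from compound 3 to compound 4, as both values are limits: the limit of >= 40000 nM in this assay, at which 4 of the 4 values shown sit.

The compounds shown leave open whether methyl in place of hydrogen on a saturated ring carbon shifts the read-out at all.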